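Acetyl to cyclobutylcarbonyl: working notes on compound 4

A few compounds are considered here, and "the series" means these few. Any claim that something is new, unique, unknown or untested is made for them only; others in the source may bear on it.

Measured so far in a physicochemical assay for solubility, read by HPLC, in phosphate buffer, measured as kinetic solubility, at pH 7.4; a lower number here means a less soluble compound, a higher number a more soluble compound:
- compound 1 `CCOC(=O)c1cc(-c2ccc(F)cc2)n(-c2ccc(S(N)(=O)=O)cc2)c1C`: 12600 nM
- compound 2 `Cc1c(C(=O)O)cc(-c2cccc(Cl)c2)n1-c1ccc(S(N)(=O)=O)cc1`: 100000 nM
- compound 3 `CC(=O)c1cc(-c2ccc(S(N)(=O)=O)cc2)n(-c2ccc(Cl)cc2)n1`: 86800 nM

Compound 3, at 86800 nM, lies within the scatter of compound 2, at 100000 nM. Compound 3 stands well clear of compound 1, at 12600 nM, with a gap beyond the scatter. The three compounds differ from one another in more than one place, so no single change can be read from these values.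

The next compound is compound 4 `NS(=O)(=O)c1ccc(-c2cc(C(=O)C3CCC3)nn2-c2ccc(Cl)cc2)cc1`. It carries cyclobutyl in place of methyl on a carbonyl carbon, which also reads as acetyl to cyclobutylcarbonyl. Within the data shown here, no measured pair isolates this change, so the size of the step is a judgment and the range is kept wide. Among the measured compounds shown here, compound 1, at 12600 nM, shows only that numbers can fall well short of that of compound 3.

A move toward a lower number, beyond the scatter, is expected, with an estimated step of a 3.9-fold lower number from compound 3 to compound 4 (0.60 log units; beyond the scatter). In this assay, compound 4 is estimated at 22000 nM, with an expected range of 6000 nM to 60000 nM.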

Compound 4, solubility: 17200 nM
Beside the measured number, compound 4's estimate is 1.3-fold (0.11 log units) above it; the measured number falls inside the stated range.
By their numbers in this assay, from the lowest: compounds 1 and 4 (each within the scatter of the next); then compounds 3 and 2 (each within the scatter of the next).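

In this assay, among these compounds, the pair of compound 3 and compound 4 is the first to differ in one place, and it gives a single readable change on a carbonyl carbon: a 5.0-fold lower number from compound 3 to compound 4 (0.70 log units; beyond the scatter). So this position is not silent in this assay, and a larger all-carbon group here goes with a lower number in this one pair. The change replaces 1 heavy atom with 4 heavy atoms and adds one four-membered non-aromatic ring of carbon only, while the counts of hydrogen-bond donors and acceptors stay at 0 on both sides and neither group carries a net charge; no measurement at hand accounts for the step, and this pair alone cannot separate the added carbon from the ring.

One pair gives one point at this position, so neither the shape of the trend with group size nor the role of the ring can be read yet. An isopropyl group or a longer chain on the carbonyl carbon would test the ring against open-chain carbon, and an amine in the same place would show whether the number moves differently once the entering group is no longer carbon only.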